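Working notes: the step from compound 2 to compound 3

This account rests on a few compounds, and the source may have more. Where it says the series, first, only, none or still open, it means among the compounds named here.

Measured in a functional assay on DU-145 cells (Homo sapiens) for cytotoxicity, read by MTT assay; on this read-out lower numbers stand for stronger inhibition and higher numbers for weaker inhibition:
- compound 1 `CC(C)=CC[C@@H](OC(=O)CCO)C1=CC(=O)c2c(O)ccc(O)c2C1=O`: 55300 nM
- compound 2 `CC(C)=CC[C@@H](OC(=O)CC(O)c1ccccc1)C1=CC(=O)c2c(O)ccc(O)c2C1=O`: 17000 nM

Within the data shown here, compound 2 holds the lower of the two numbers so far. Compound 3 `CC(C)=CC[C@@H](OC(=O)CC(C)(O)C(C)C)C1=CC(=O)c2c(O)ccc(O)c2C1=O` differs from it as follows: 1-hydroxy-1,2-dimethylpropyl in place of hydroxy(phenyl)methyl on a saturated chain carbon bound to a carbonyl carbon. The change sits on a saturated chain carbon bound to a carbonyl carbon. Among the measured compounds shown here, the only measured step that bears on it is the modest 3.3-fold lower number from compound 1 to compound 2 (0.51 log units; beyond the scatter), which introduced the phenyl that now leaves. For the measured compounds named here, no measured compound carries a ring-free group there, so only a small rise in this assay is expected, possibly none beyond the scatter. The expected change is a 1.3-fold higher number from compound 2 to compound 3 (0.11 log units; within the scatter). The estimate for compound 3 is 22000 nM, with a range of 8000 nM to 55000 nM.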

Compound 3, half-maximal inhibitory concentration: 16900 nM
Compound 3: the middle estimate sits 1.3-fold (0.11 log units) above what was measured, and the stated range covers the measured number.
By their numbers in this assay, from the lowest: compounds 3 and 2 (each within the scatter of the next); then compound 1.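

In this assay replacing hydroxy(phenyl)methyl with 1-hydroxy-1,2-dimethylpropyl gives a 1.0-fold lower number from compound 2 to compound 3 (0.00 log units; within the scatter) and so shows that a phenyl ring is not needed at this place to hold the number of compound 2. Against hydroxymethyl, the ring-free group gives a 3.3-fold lower number from compound 1 to compound 3 (0.51 log units; beyond the scatter) and thus shares the gain first seen with the phenyl group. No measurement available here explains this equivalence. The compounds shown leave open whether the hydroxy group matters to either gain. Also open, on these data alone, is how a longer chain or an amine would read on a saturated chain carbon bound to a carbonyl carbon.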